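The compounds below may be only part of what the source reports. "The series", "measured", "known", "first", "only" and "open" are said of these compounds alone.

Three compounds have been measured in a functional assay for inhibition, with Homo sapiens as the target; a higher number here means a weaker inhibitor, a lower number a stronger inhibitor:

Compound 1, `CC1CCN(c2ccc(Nc3nccc(-c4ccco4)n3)cc2)CC1`: 1800 nM
Compound 2, `CC1CCN(c2cccc(Nc3nccc(-c4ccco4)n3)c2)CC1`: 5000 nM
Compound 3, `CC1CCN(c2ccc(Nc3nccc(-c4cccnc4)n3)cc2)CC1`: 500 nM

Compound 1 and compound 3 share a core and differ in a single place: pyridin-3-yl in place of furan-2-yl on an aromatic carbon. This change gave a 3.6-fold lower number from compound 1 to compound 3 (0.56 log units; beyond the scatter), a step in the direction of stronger inhibition. Compound 2 is built from the same atoms as compound 1, joined differently; the difference between the two cores is not broken down here. Among the three, compound 2 gives the highest number, with compound 1 nearest to it and compound 3 furthest away.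

Compound 4, `CC1CCN(c2cccc(Nc3nccc(-c4cccnc4)n3)c2)CC1`, has not yet been measured in this assay. It stands to compound 2 as compound 3 stands to compound 1: pyridin-3-yl in place of furan-2-yl on an aromatic carbon. The surroundings of the place are described in the same words for both pairs, so this is the same change carried out on the core of compound 2. Going by the values given here, the only guide to its effect is the one step seen so far on the other core, and a single observation is a thin basis. Resting on a 3.6-fold lower number from compound 1 to compound 3 (0.56 log units; beyond the scatter), which was seen only once, the expected step for compound 4 is a 3.6-fold lower number from compound 2 to compound 4 (0.55 log units; beyond the scatter). Compound 4 is therefore estimated at 1400 nM, with a likely range from 600 nM to 3500 nM.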

Compound 4, half-maximal inhibitory concentration: 1200 nM
The estimate for compound 4 lay 1.2-fold (0.07 log units) above the measured number, within the range that was stated.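

Replacing furan-2-yl with pyridin-3-yl on the core of compound 2 gave, in this assay, a 4.2-fold lower number from compound 2 to compound 4 (0.62 log units; beyond the scatter), a step towards stronger inhibition. Set beside the earlier step, the change did much the same on both cores, and the two steps cannot be told apart, so in this small set its effect carried over from one core to the other: the same change on two cores in this assay, a 3.6-fold lower number (0.56 log units; beyond the scatter) from compound 1 to compound 3 and a 4.2-fold lower number (0.62 log units; beyond the scatter) from compound 2 to compound 4, 1.2-fold (0.06 log units) apart, within the scatter of two such steps. Going by these compounds alone, this rests on only two matched pairs in a single assay, so it shows that the step held on these two cores, but not that it would hold on other cores, and it does not explain why pyridin-3-yl gives the lower number.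

The compounds shown leave open whether other aromatic groups in the same place, such as phenyl or pyridin-4-yl, would give a similar step or a different one. They also leave open whether the step would survive a larger change elsewhere in the molecule, for example a carboxylic acid or an amine in place of the methyl group.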